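The source may report more compounds than this note shows. Statements on the series, on what has been measured and on what is new or still open speak of the compounds shown alone.

Measured compounds:
- Compound 1, `O=S(=O)(NCCCNCc1cccc(Cl)c1)c1cc(C(F)(F)F)cc(C(F)(F)F)c1`: 6900 nM
- Compound 2, `COc1cccc(CNCCCNS(=O)(=O)c2cc(C(F)(F)F)cc(C(F)(F)F)c2)c1`: 4500 nM

Both numbers come from a functional assay on BE(2)-C cells (Homo sapiens) for inhibition, read by MTT assay, with a stated time of 72 h; on this read-out higher numbers stand for weaker inhibition of growth and lower numbers for stronger inhibition of growth. Compound 2 stands together with compound 1: the step of a 1.5-fold lower number from compound 1 to compound 2 (0.19 log units; within the scatter) is the only comparison shown, and it is too small to separate the two compounds.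

Compound 3, `O=S(=O)(NCCCNCc1ccc(Cl)cc1)c1cc(C(F)(F)F)cc(C(F)(F)F)c1`, has not yet been measured in this assay. It differs from compound 2 by 4-chlorophenyl in place of 3-methoxyphenyl on a saturated chain carbon bound to an amine nitrogen, so the ring that carries the change keeps the same shape and only its single substituent, and where that substituent sits, is altered. Within the data shown here, the one measured step that bears on this, from compound 1 to compound 2, swapped a chloro for a methoxy on the same ring and gave a 1.5-fold lower number from compound 1 to compound 2 (0.19 log units; within the scatter), nothing beyond the scatter. Among the measured compounds shown here, no measured pair shows a chloro moving from one place on the ring to another. The expectation is therefore a step of a 1.2-fold higher number from compound 2 to compound 3 (0.09 log units; within the scatter) in this assay, not clearly in either direction. For compound 3 the estimated value is 5500 nM, with a range from 2500 nM to 12000 nM.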

Compound 3, concentration for 50% growth inhibition: 2900 nM
The estimate for compound 3 lay 1.9-fold (0.28 log units) above the measured number; the measured number falls inside the stated range.
By their numbers in this assay, from the lowest: compounds 3, 2 and 1 (each within the scatter of the next, the first and the last beyond it).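

Moving the chloro gives the first step in this series that clears the scatter: 4-chlorophenyl in place of 3-chlorophenyl, on a saturated chain carbon bound to an amine nitrogen, gives a 2.4-fold lower number from compound 1 to compound 3 (0.38 log units; beyond the scatter) in this assay. Where the chloro sits on this ring therefore makes a modest difference to the number, which the earlier swap of chloro for methoxy could not show, while the step of a 1.6-fold lower number from compound 2 to compound 3 (0.19 log units; within the scatter) leaves compound 3 and compound 2 unseparated. Nothing measured here explains the effect of moving the chloro.

As far as these compounds go, it remains open whether 4-methoxyphenyl would differ from 3-methoxyphenyl as the two chlorophenyl groups do. From the compounds shown here alone, it is also open whether 4-fluorophenyl or 4-bromophenyl would give numbers close to that of compound 3.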